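The source may hold more compounds than are shown below. What is called first, only, known or untested is meant among the compounds shown, and "the series" means these compounds.

Measured compounds:
- compound 1 `COc1cccc(/C=C/C(=O)c2ccc(OCCn3cc(CN4C(=O)/C=C/C(C)(C)C/C=C(\C)CC/C=C/4C)nn3)cc2O)c1` — 1.01 ug/mL
- compound 2 `COc1cc(/C=C/C(=O)c2ccc(OCCn3cc(CN4C(=O)/C=C/C(C)(C)C/C=C(\C)CC/C=C/4C)nn3)cc2O)cc(OC)c1OC` — 1.44 ug/mL
- compound 3 `COc1ccc(/C=C/C(=O)c2ccc(OCCCN3C(=O)/C=C/C(C)(C)C/C=C(\C)CC/C=C/3C)cc2)cc1` — 1.73 ug/mL

All three were tested in a functional assay on HepG2 cells (Homo sapiens) for antiproliferative activity; on this read-out higher numbers stand for weaker inhibition and lower numbers for stronger inhibition. In this assay compound 1 gives 1.01 ug/mL, compound 2 gives 1.44 ug/mL and compound 3 gives 1.73 ug/mL; the three values lie within the usual scatter of one another, so compound 3 cannot be told apart from the other two.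

Compound 4 `COc1cccc(/C=C/C(=O)c2ccc(OCCCN3C(=O)/C=C/C(C)(C)C/C=C(\C)CC/C=C/3C)cc2)c1` is not yet measured. It differs from compound 3 in one place: 3-methoxyphenyl in place of 4-methoxyphenyl on a double-bonded chain carbon bound to a double-bonded chain carbon. Among the measured compounds shown here, the only measured step that touches the same spot is the one from compound 1 to compound 2, where a 3,4,5-trimethoxyphenyl replaced a 3-methoxyphenyl; that step gave a 1.4-fold higher number from compound 1 to compound 2 (0.15 log units; within the scatter). For the measured compounds named here, there is no measured pair that swaps a 4-methoxyphenyl for a 3-methoxyphenyl directly, so the expectation rests on that single nearby step, which stayed within the scatter.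

On that basis compound 4 is expected to show no step beyond the scatter, a 1.1-fold lower number from compound 3 to compound 4 (0.03 log units; within the scatter). The estimate for compound 4 in this assay is 1.6 ug/mL, with a likely range from 0.8 ug/mL to 3.4 ug/mL.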

Compound 4, half-maximal inhibitory concentration: 1.38 ug/mL
Compound 4: middle estimate off by 1.2-fold (0.06 log units), on the high side; the measured number falls inside the stated range.
By their numbers in this assay, from the lowest: compounds 1, 4, 2 and 3 (each within the scatter of the next).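

In this assay, exchanging the 4-methoxyphenyl for a 3-methoxyphenyl on a double-bonded chain carbon bound to a double-bonded chain carbon gives a 1.3-fold lower number from compound 3 to compound 4 (0.10 log units; within the scatter) in this pair. The earlier step, a 1.4-fold higher number from compound 1 to compound 2 (0.15 log units; within the scatter), changed how many methoxy groups the phenyl ring carries, whereas this one keeps a single methoxy group and changes only where it sits, and that move also cannot be told from assay noise. No available evidence explains this result.

All the phenyl rings shown at this place carry only methoxy groups, so it remains open whether an amine or a carboxylic acid on that ring would move the number beyond the scatter. Compound 1 and compound 4 share the 3-methoxyphenyl but differ in more than one place, so the contribution of the rest of the molecule also stays unresolved.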